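A few compounds are considered here, and "the series" means these few. Any claim that something is new, unique, unknown or untested is made for them only; others in the source may bear on it.

Compound 2 `c1ccc(-c2cn3ccnc3c(-c3ccc4ncn(C5CCCCC5)c4c3)n2)cc1` is the compound with the highest number among the three measured in a functional assay on MDA-MB-231 cells (Homo sapiens) for inhibition, read by sulforhodamine B assay, with a stated time of 48 h, tested at 10 uM (a lower number here means less inhibition, a higher number more inhibition at the concentration tested (going by the name of the read-out)), where compound 2 gives 41.5%. Compound 1 `Brc1cn2ccnc2c(-c2ccc3ncn(C4CCCCC4)c3c2)n1` gives 24.2%, and compound 3 `c1ccc2c(-c3cn4ccnc4c(-c4ccc5ncn(C6CCCCC6)c5c4)n3)cccc2c1` gives 20.8%. Compound 4 `COc1ccccc1-c1cn2ccnc2c(-c2ccc3ncn(C4CCCCC4)c3c2)n1` has not yet been measured. The change from compound 2 to compound 4 is methoxy in place of hydrogen on an aromatic carbon. Going by the values given here, no measured step puts a methoxy group at this position, so the bearing of the data is indirect. The steps that alter the same aromatic carbon are a number 17.3 percentage points higher from compound 1 to compound 2 (beyond the scatter) and a number 20.7 percentage points lower from compound 2 to compound 3 (beyond the scatter); the second shows a lower number when naphthalen-1-yl stands in place of phenyl, while the first shows a higher number when phenyl stands in place of bromo. A methoxy group is a small addition to the phenyl of compound 2, so the expected step is a number 6.5 percentage points lower from compound 2 to compound 4 (within the scatter), likely a slight decrease or none beyond the scatter. The estimate for compound 4 in this assay is 35%, with a range from 15% to 55%.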

Compound 4, a percentage reported as inhibition, at one concentration (the size of the read-out at that concentration, not a potency): 15.9%
Compound 4: middle estimate off by 19.1 percentage points, on the high side, and the stated range covers the measured number.
By their numbers in this assay, from the lowest: compounds 4, 3 and 1 (each within the scatter of the next); then compound 2.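

In this assay, methoxy in place of hydrogen, ortho to a large group, on the phenyl of compound 2 gives a number 25.6 percentage points lower from compound 2 to compound 4 (beyond the scatter), so this one addition is enough to remove the advantage of compound 2. The result also places compound 4 with the other two compounds, with a number 4.9 percentage points lower from compound 3 to compound 4 (within the scatter) and a number 8.3 percentage points lower from compound 1 to compound 4 (within the scatter), which leaves the plain phenyl as the only one of the four groups shown on this aromatic carbon that stands apart. Nothing available explains this change in terms of any measured property.

The compounds shown leave open whether the drop is tied to methoxy itself or to its place on the ring, as no other position carries it. They also leave open whether a smaller group such as fluoro, or a hydroxy or an amine, in the same place would keep the number of compound 2 41.5%.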